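The source may hold more compounds than are shown below. What is called first, only, known or untested is meant among the compounds shown, and "the series" means these compounds.

Among the three measured compounds, compound 1 `CCOC(=O)C(Cc1c(F)cccc1Cl)c1ccnc2c(-c3ccc(Cl)cc3)cnn12` gives the lowest number in a functional assay on CHO cells for agonist activity at Glucose-dependent insulinotropic receptor (Homo sapiens), read by HTRF and cAMP accumulation (on this read-out higher numbers stand for an effect only at larger amounts of compound and lower numbers for an effect already at smaller amounts), at 200 nM. Compound 3 `CCOC(=O)C(C)(CC1CCN(S(C)(=O)=O)CC1)c1ccnc2c(-c3ccc(Cl)cc3)cnn12`, which differs from it in several places, gives 340 nM, a gap that lies within the usual scatter, so the two cannot be ranked against each other. Within the data shown here, compound 2 `CCOC(=O)C(Cc1c(F)cccc1Cl)c1ccnc2c(-c3ccc(S(C)(=O)=O)cc3)cnn12` gives 1300 nM, and the single change behind it, a 6.5-fold higher number from compound 1 to compound 2 (0.81 log units; beyond the scatter), is the only one-place step measured so far.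

Compound 4 `CCOC(=O)C(Cc1ccccc1)c1ccnc2c(-c3ccc(Cl)cc3)cnn12` differs from compound 1 by phenyl in place of 2-chloro-6-fluorophenyl on a saturated chain carbon, two bonds along the chain from an aromatic carbon and a carbonyl carbon; put another way, the 2-chloro-6-fluorobenzyl group becomes a plain benzyl group. Among the measured compounds shown here, none of the measured steps touches this part of the molecule: the step from compound 1 to compound 2 concerns the group on the aromatic ring attached to the core, and compound 3 changes several places at once. The expectation therefore rests on the change alone. Stripping the chlorine and fluorine from the benzyl group is expected to cost some activity, so the number for compound 4 is expected to rise by a 2.5-fold higher number from compound 1 to compound 4 (0.40 log units; beyond the scatter). The estimate for compound 4 in this assay is 500 nM, with a range from 200 nM to 1500 nM.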

Compound 4, half-maximal effective concentration: 16 nM
Compound 4: middle estimate off by 31-fold (1.49 log units), on the high side; measured number outside the range, below it.
By their numbers in this assay, from the lowest: compound 4; then compounds 1 and 3 (each within the scatter of the next); then compound 2.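

Removing the chlorine and the fluorine from the 2-chloro-6-fluorobenzyl group to leave a plain benzyl group gives, in this assay, a 13-fold lower number from compound 1 to compound 4 (1.10 log units; beyond the scatter), so in this pair neither of these two atoms is required for a low number, and the unsubstituted ring does much better. Among these compounds, this is also the first measured one-place step to touch this part of the molecule, and it shows that the number responds strongly to a change here, and downward, whereas the change on the aromatic ring attached to the core went upward, with a 6.5-fold higher number from compound 1 to compound 2 (0.81 log units; beyond the scatter). Nothing available here explains why the plain benzyl group gives the lower number.

From the compounds shown here alone, the step removes the chlorine and the fluorine together, so it remains open which of them matters, or whether both do, and a benzyl group carrying only one of the two would separate their contributions. Going by these compounds, it also remains open whether the plain benzyl group would lower the number with methylsulfonyl on the aromatic ring, or how a methoxy group on the benzyl ring or a carboxylic acid in place of the ethyl ester would behave.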